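Hydrogen in place of methyl on compound 2

The source may report more compounds than this note shows. Statements on the series, on what has been measured and on what is new or still open speak of the compounds shown alone.

Compound 1 `Cc1nn2c(-c3nc4cc(C(F)(F)F)ccc4[nH]3)c(-c3ccc(F)cc3)nc2s1`: 7300 nM
Compound 2 `Cc1ccc2[nH]c(-c3c(-c4ccc(F)cc4)nc4sc(C)nn34)nc2c1`: 7700 nM

For the measured compounds named here, in a functional assay on A-375 cells (Homo sapiens) for antiproliferative activity, read by MTT assay (a lower number here means a stronger inhibitor, a higher number a weaker inhibitor), compound 2 gives 7700 nM, and the only other measured compound lies within the scatter of it. The next compound, compound 3 `Cc1nn2c(-c3nc4ccccc4[nH]3)c(-c3ccc(F)cc3)nc2s1`, differs from compound 2 in one place: hydrogen in place of methyl on an aromatic carbon. In words, this is hydrogen in place of methyl on an aromatic carbon. Going by the values given here, one measured step bears on this change, also a swap of a group on an aromatic carbon: a 1.1-fold higher number from compound 1 to compound 2 (0.02 log units; within the scatter). Among the compounds with values here, that step, methyl in place of trifluoromethyl, stayed within the scatter, but no measured compound yet carries hydrogen there, so the evidence is thin. No change beyond the scatter is expected in this assay. The expected step is a 1.0-fold lower number from compound 2 to compound 3 (0.01 log units; within the scatter). Compound 3 is estimated at 7500 nM, with an expected range of 3500 nM to 16000 nM.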

Compound 3, half-maximal inhibitory concentration: 22200 nM
The estimate for compound 3 lay 3.0-fold (0.47 log units) below the measured number; the whole stated range lies below it.
By their numbers in this assay, from the lowest: compounds 1 and 2 (each within the scatter of the next); then compound 3.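

In this assay, for the compounds shown here, hydrogen in place of methyl gives a 2.9-fold higher number from compound 2 to compound 3 (0.46 log units; beyond the scatter) and is the first change to move the number beyond the scatter. Hydrogen in place of trifluoromethyl gives a 3.0-fold higher number from compound 1 to compound 3 (0.48 log units; beyond the scatter) and points the same way, so this aromatic carbon is not indifferent to what it carries. Methyl and trifluoromethyl remain within the scatter of each other, and among these three compounds either group goes with a lower number than hydrogen.

Going by these compounds, whether this holds for other groups on the same carbon stays open, for instance a chlorine atom, a methoxy group, an amine or a longer chain such as propyl. Why hydrogen stands apart from both groups also stays open, as nothing given here bears on the cause.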